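Chloro in Place of Methyl on the Benzyl Arm

The compounds below may be only part of what the source reports. "The series", "measured", "known", "first", "only" and "open" are said of these compounds alone.

Compound 1 `Cc1ccccc1CSc1nnc(-c2ccc3c(c2)OCCO3)o1` is the reference point. In a functional assay on HeLa cells (Homo sapiens) for antiproliferative activity, read by MTT assay, with a stated time of 48 h (a lower number here means a stronger inhibitor, a higher number a weaker inhibitor), compound 1 gives 19000 nM, the lowest of the three numbers measured; compound 3 `Clc1ccc(CSc2nnc(-c3ccc4c(c3)OCCO4)o2)cc1` gives 28500 nM and compound 2 `c1ccc(CSc2nnc(-c3ccc4c(c3)OCCO4)o2)cc1` gives 40300 nM. The gap to compound 3 is within the scatter, the gap to compound 2 beyond it.

Compound 4 `Clc1ccccc1CSc1nnc(-c2ccc3c(c2)OCCO3)o1` is not yet measured. It differs from compound 1 by chloro in place of methyl on an aromatic carbon, on an aromatic carbon of a six-membered aromatic ring of carbon only, ortho to a large group.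

Going by the values given here, two measured steps bear on this. Removing the methyl gave a 2.1-fold higher number from compound 1 to compound 2 (0.33 log units; beyond the scatter). Adding a chloro to an aromatic carbon gave a 1.4-fold lower number from compound 2 to compound 3 (0.15 log units; within the scatter), though in a different place from the chloro entering compound 4. Swapping the whole arm gave a 1.5-fold higher number from compound 1 to compound 3 (0.18 log units; within the scatter), within the scatter. Taken together, no step beyond the scatter is expected in this assay for compound 4, with a slight lean toward a higher number. Compound 4 is therefore estimated at 24000 nM, within 12000 nM to 48000 nM, which means an expected 1.3-fold higher number from compound 1 to compound 4 (0.10 log units; within the scatter).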

Compound 4, half-maximal inhibitory concentration: 36800 nM
Compound 4: middle estimate off by 1.5-fold (0.19 log units), on the low side; low and high end bracket the measured number.
By their numbers in this assay, from the lowest: compounds 1, 3, 4 and 2 (each within the scatter of the next, the first and the last beyond it).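

In this assay, chloro on this aromatic carbon, ortho to a large group, gives a 1.1-fold lower number from compound 2 to compound 4 (0.04 log units; within the scatter) and a 1.9-fold higher number from compound 1 to compound 4 (0.29 log units; within the scatter) and so cannot be told apart from either hydrogen or methyl. The 2-chlorophenyl in place of 4-chlorophenyl gives a 1.3-fold higher number from compound 3 to compound 4 (0.11 log units; within the scatter) and thus does not separate the two chloro placements on the ring. Going by these compounds alone, at this place, methyl remains the only group with a step from hydrogen beyond the scatter, a 2.1-fold higher number from compound 1 to compound 2 (0.33 log units; beyond the scatter) being the step in question, and chloro does not share that distinction.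

No measurement here accounts for the steps at this position. Going by these compounds, whether a methoxy group, an amine or a carboxylic acid on this carbon, or a longer chain in place of the benzyl link, would move the number beyond the scatter remains open.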